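The source may hold more compounds than are shown below. What is called first, only, known or untested is meant among the compounds shown, and "the series" means these compounds.

Measured so far:
compound 1, `COc1ccccc1Nc1ncnc2cc(OC)c(OCCCCC(=O)Nc3ccc(S(N)(=O)=O)cc3)cc12`: in a functional assay on A549 cells (Homo sapiens) for antiproliferative activity, read by MTT assay, with a stated time of 72 h (a higher number here means a weaker inhibitor, a lower number a stronger inhibitor), compound 1 gives 24100 nM.
compound 2, `COc1cc2ncnc(Nc3ccc(OCc4cccc(F)c4)c(Cl)c3)c2cc1OCCCCC(=O)Nc1ccc(S(N)(=O)=O)cc1`: compound 2 gives 7860 nM.
compound 3, `NS(=O)(=O)c1ccc(NC(=S)Nc2ccc3ncnc(Nc4ccc(F)c(Cl)c4)c3c2)cc1`: compound 3 gives only a limit of the assay, > 40000 nM.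

Compound 3 thus stands at the limit of this assay, (the limit of > 40000 nM in this assay, at which 1 of the 3 values shown sits), the only one of the three for which no number came out. Compound 4, `NS(=O)(=O)c1ccc(NC(=S)Nc2ccc3ncnc(Nc4cccc(Cl)c4)c3c2)cc1`, is not yet measured. It differs from compound 3 as follows: hydrogen in place of fluoro on an aromatic carbon. Going by the values given here, no measured pair in this set differs in just one place, so the size of this step has no precedent among the values shown; a step no larger than the scatter is expected, in either direction. Compound 4 is therefore expected to sit at 40000 nM, between 15000 nM and 100000 nM, most likely again reported as a limit. The step from compound 3 to compound 4 is expected to be a number no higher from compound 3 to compound 4 (the limit leaves the size open).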

Compound 4, half-maximal inhibitory concentration: > 40000 nM
Compound 4: only a limit was reported; the forecaster's own chance of this, stated with the estimate: 60%; the middle value lies on the limit itself.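

In this assay, going by these compounds alone, compound 3 and compound 4 both stand at a limit, so no step between them can be read: the limit of > 40000 nM in this assay, at which 2 of the 4 values shown sit. The compounds shown leave open what hydrogen in place of fluoro does to antiproliferative activity.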